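Methyl for Ethoxy on the Core of Compound 1

This account rests on a few compounds, and the source may have more. Where it says the series, first, only, none or still open, it means among the compounds named here.

Compound 1 `CCOc1ccc(-c2nn3cc(-c4cccc(N)c4)nc3s2)cc1` is the starting point. In a functional assay on FM3A cells (Mus musculus) for inhibition, read by cell counting, with a stated time of 2 days (on this read-out higher numbers stand for weaker inhibition and lower numbers for stronger inhibition), compound 1 gives >= 250000 nM, which is a limit of the assay and not a measured number. Compound 1 sits at the limit of >= 250000 nM in this assay, at which 1 of the 3 values shown sits. Compound 2 `C=C(Br)C(=O)Nc1cccc(-c2cn3nc(-c4ccc(OCC)cc4)sc3n2)c1` carries a (1-bromoethenyl)carbonyl in place of hydrogen on a nitrogen on an aromatic ring, and in this assay compound 2 gives 1100 nM; the step is an at least 220-fold lower number from compound 1 to compound 2 (2.35 log units; beyond the scatter). Going by the values given here, compound 3 `COc1ccc(-c2csc3nc(-c4cccc(N)c4)cn23)cc1`, built on a core in which the rings are joined differently and bearing a methoxy group, gives 11000 nM in this assay; no single-point step connects it to compound 1, so its value stands on its own.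

The unmeasured compound 4 `Cc1ccc(-c2nn3cc(-c4cccc(N)c4)nc3s2)cc1` differs from compound 1 in one place: methyl in place of ethoxy on an aromatic carbon, para to a large group. Among the compounds with values here, the only measured step alters the nitrogen of compound 1, not this ring position, so it does not bear on the exchange. Nothing measured here speaks for stronger inhibition after this swap. Compound 4 is therefore expected to stay at or near the limit, with an expected step of a number no higher from compound 1 to compound 4 (the limit leaves the size open). The estimate for compound 4 in this assay is 250000 nM, within a range from 50000 nM to 1000000 nM.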

Compound 4, half-maximal inhibitory concentration: 5800 nM
The estimate for compound 4 lay 43-fold (1.63 log units) above the measured number; the measured number lies below the stated range.
By their numbers in this assay, from the lowest: compound 2; then compounds 4 and 3 (each within the scatter of the next). At a limit, above all of these: compound 1.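

In this assay, methyl in place of ethoxy on this aromatic carbon, para to a large group, gives an at least 43-fold lower number from compound 1 to compound 4 (1.63 log units; beyond the scatter), a large step beyond the scatter. The earlier compounds had shown a step of this kind only at the nitrogen on the aromatic ring, so this position is a second place where a single change moves the number, here with that nitrogen left as it is. Compound 1 stands at a limit and not at a measured number, so the step has a lower bound but no fixed size: the limit of >= 250000 nM in this assay, at which 1 of the 4 values shown sits.

Among the compounds on this core, only ethoxy and methyl are shown at this position, so it stays open how hydrogen, a chlorine atom, an amine or a longer chain would read there. As far as these compounds go, it also stays open whether methyl at this position and the (1-bromoethenyl)carbonyl on the nitrogen would, taken together, give a lower number than either change alone.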